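The source may hold more compounds than are shown below. What is called first, only, known or untested is meant among the compounds shown, and "the series" means these compounds.

Compound 2 `CCOc1ncc(-c2nc(C(F)(F)F)sc2N2CCN(C(=O)Cn3cnc4ccccc43)[C@H](C)C2)cn1` is one of two closely related antagonists. In a functional assay on CHO-K1 cells for antagonist activity at C-X-C chemokine receptor type 3 (Homo sapiens), read by FLIPR, with a stated time of 10 min (on this read-out higher numbers stand for weaker inhibition and lower numbers for stronger inhibition), compound 2 gives 2 nM, level with compound 1 `CCOc1ncc(-c2nc(C(F)(F)F)sc2N2CCN(C(=O)Cn3cnc4cccnc43)[C@H](C)C2)cn1`, which in this assay gives 2 nM; the step of no change at the digits printed from compound 1 to compound 2 (within the scatter) stayed within the scatter. Compound 3 `CCOc1ncc(-c2nc(C(F)(F)F)sc2N2CCN(C(=O)Cn3ccc4cccnc43)[C@H](C)C2)cn1` carries a further rearrangement of the same ring pair: a group of 9 heavy atoms (7 carbon, 2 nitrogen; one five-membered aromatic ring with 1 hetero atom, one six-membered aromatic ring with 1 hetero atom) in place of a group of 9 heavy atoms (7 carbon, 2 nitrogen; one five-membered aromatic ring with 2 hetero atoms, one six-membered aromatic ring of carbon only), on a saturated chain carbon bound to a carbonyl carbon. Going by the values given here, the only step measured at this position, no change at the digits printed from compound 1 to compound 2 (within the scatter), left potency unchanged. For compound 3 a step of a 1.5-fold higher number from compound 2 to compound 3 (0.18 log units; within the scatter) is therefore expected, meaning no change beyond the scatter. Compound 3 is estimated at 3 nM, ranging from 1 nM to 10 nM.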

Compound 3, half-maximal inhibitory concentration: 3.8 nM
Compound 3: middle estimate off by 1.3-fold (0.10 log units), on the low side; low and high end bracket the measured number.
By their numbers in this assay, from the lowest: compounds 1, 2 and 3 (each within the scatter of the next).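

The ring pair in compound 3, with only one hetero atom in its five-membered ring and one in its six-membered ring, gives a 1.9-fold higher number from compound 2 to compound 3 (0.28 log units; within the scatter) and a 1.9-fold higher number from compound 1 to compound 3 (0.28 log units; within the scatter). Until now, only pairs with two hetero atoms in the five-membered ring had been compared at this position. All three ring pairs now lie within the scatter of one another, so this position accepts either arrangement on this read-out. No available evidence accounts for this. The compounds shown leave open whether a single phenyl ring, or an amine or carboxylic acid, on that saturated chain carbon would fare the same.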